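The source may hold more compounds than are shown below. What is called first, only, known or untested is meant among the compounds shown, and "the series" means these compounds.

Measured compounds:
compound 1, `CCCCS(=O)(=O)c1sc2nc(-c3nccs3)cc(-c3cnc(C)n3C)c2c1N`, giving 32 nM in an assay for inhibition of 15-hydroxyprostaglandin dehydrogenase [NAD(+)] (Homo sapiens), read by fluorescence, with a stated time of 15 min, in the presence of a further agent that is not named here; a lower number here means a stronger inhibitor, a higher number a weaker inhibitor
compound 2, `COCCC[S+]([O-])c1sc2nc(-c3nccs3)cc(-c3cnc(C)n3C)c2c1N`, giving 3.3 nM in this assay
compound 3, `CCCC[S+]([O-])c1sc2nc(-c3nccs3)cc(-c3ccc(COC(=O)CN(C)C)cc3)c2c1N`, giving 3.5 nM in this assay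

Compound 3 sits with the second highest of the three numbers. Its nearest neighbour is compound 2, whose value lies within the scatter of that of compound 3, so no order between these two can be read from the data. Compound 1 stands beyond the scatter from compound 3, with the higher number.

Compound 4, `CCCC[S+]([O-])c1sc2nc(-c3nccs3)cc(-c3ccc(CNC(C)=O)cc3)c2c1N`, is not yet measured in this assay. It differs from compound 3 in one place: acetamido in place of (((dimethylamino)methyl)carbonyl)oxy on a saturated chain carbon bound to an aromatic carbon. For the measured compounds named here, the only step that is fully measured, a 9.7-fold lower number from compound 1 to compound 2 (0.99 log units; beyond the scatter), concerns the chain on the sulfur and the change from sulfone to sulfoxide, so it does not bear on the change from compound 3 to compound 4. Compound 2 and compound 3 differ in two places at once, so their near-equal values give no isolated reading of the group on the aryl ring either. With nothing directly comparable, the expectation for compound 4 is a step of a 1.4-fold higher number from compound 3 to compound 4 (0.15 log units; within the scatter), that is, no movement beyond the scatter. The estimate for compound 4 in this assay is therefore 5 nM, within a range from 1.5 nM to 16 nM.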

Compound 4, half-maximal inhibitory concentration in the 15-hydroxyprostaglandin dehydrogenase [NAD(+)] assay: 2.5 nM
Beside the measured number, compound 4's estimate is 2.0-fold (0.30 log units) above it; low and high end bracket the measured number.
By their numbers in the 15-hydroxyprostaglandin dehydrogenase [NAD(+)] assay, from the lowest: compounds 4, 2 and 3 (each within the scatter of the next); then compound 1.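

In the 15-hydroxyprostaglandin dehydrogenase [NAD(+)] assay, acetamido in place of (((dimethylamino)methyl)carbonyl)oxy on a saturated chain carbon bound to an aromatic carbon gives a 1.4-fold lower number from compound 3 to compound 4 (0.15 log units; within the scatter), so no difference in inhibition can be read between the two groups. For the compounds shown here, this is the first reading of this position on its own, since compound 2 and compound 3 differ in two places at once; here acetamido, with 1 hydrogen-bond donor, replaces (((dimethylamino)methyl)carbonyl)oxy, with 0 hydrogen-bond donors, and inhibition stays in the same low range within the scatter. The same exchange does register in a physicochemical assay for solubility, read by LC-MS, with a stated time of 16 h, at pH 7 (on this read-out lower numbers stand for lower solubility and higher numbers for higher solubility), where compound 3 gives 6 ug/mL and compound 4 gives 2.16 ug/mL, so the two compounds separate: the measured solubility of compound 3, 6 ug/mL, and of compound 4, 2.16 ug/mL, a 2.8-fold lower number (0.44 log units; beyond the scatter)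

The compounds shown leave open whether a carboxylic acid or a free amine in this place would keep the inhibition seen for compound 3 and compound 4 while giving a higher solubility. They also leave open whether the amide hydrogen of acetamido matters, which an N-methyl acetamide in the same place would test.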